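The source may hold more compounds than are shown below. What is called first, only, known or untested is meant among the compounds shown, and "the series" means these compounds.

Measured so far in an assay on HEK293F cells for inhibition of cholesterol 24-hydroxylase (Homo sapiens), read by trypan blue exclusion, with stated times of 15 min and 5 h; on this read-out lower numbers stand for stronger inhibition and higher numbers for weaker inhibition:
Compound 1 `CCNC(=O)C1CCN(c2cncnc2-c2ccccc2)CC1` gives 58 nM.
Compound 2 `O=C(Nc1ccccc1)C1CCN(c2cncnc2-c2ccccc2)CC1` gives 28 nM.
Compound 3 `CN(C)C(=O)C1CCN(c2cncnc2-c2ccccc2)CC1` gives 16 nM.

Compound 3 holds the lowest of the three numbers. One gap is a 1.8-fold lower number from compound 2 to compound 3 (0.24 log units; within the scatter), which the scatter covers, so the two cannot be ranked; the other gap is a 3.6-fold lower number from compound 1 to compound 3 (0.56 log units; beyond the scatter), which lies beyond it.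

Compound 4 `CCN(C)C(=O)C1CCN(c2cncnc2-c2ccccc2)CC1` is the next candidate. Its difference from compound 3 is methyl in place of hydrogen on a saturated chain carbon bound to an amide-type nitrogen. Two of the measured steps touch the same amide nitrogen. a 3.6-fold lower number from compound 1 to compound 3 (0.56 log units; beyond the scatter) came with exchanging a nitrogen carrying one carbon group and one hydrogen for one carrying two carbon groups. a 2.1-fold lower number from compound 1 to compound 2 (0.32 log units; beyond the scatter) came with exchanging the carbon group on a nitrogen that kept its hydrogen. Among the compounds with values here, compound 4 keeps the nitrogen with two carbon groups as in compound 3 and only lengthens one of them, so the closest precedent is the flat comparison of compound 2 and compound 3 rather than the larger step from compound 1. In this assay, therefore, no step beyond the scatter is expected, with at most a slight drift upward.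

Compound 4 is expected to give 20 nM, within 8 nM to 50 nM. The expected step is a 1.3-fold higher number from compound 3 to compound 4 (0.10 log units; within the scatter).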

Compound 4, half-maximal inhibitory concentration: 14 nM
Compound 4: middle estimate off by 1.4-fold (0.15 log units), on the high side; low and high end bracket the measured number.
By their numbers in this assay, from the lowest: compounds 4, 3 and 2 (each within the scatter of the next); then compound 1.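

In this assay, a 1.1-fold lower number from compound 3 to compound 4 (0.06 log units; within the scatter) shows that methyl in place of hydrogen on a saturated chain carbon bound to an amide-type nitrogen brings no readable change, so dimethylamino and ethyl(methyl)amino on the carbonyl carbon cannot be told apart, and anilino also remains unseparated from ethyl(methyl)amino, with a 2.0-fold lower number from compound 2 to compound 4 (0.30 log units; within the scatter). With a 4.1-fold lower number from compound 1 to compound 4 (0.62 log units; beyond the scatter), methyl in place of hydrogen on an amide-type nitrogen gives a second step beyond the scatter away from ethylamino, so both compounds with two carbon groups on this nitrogen now stand apart from compound 1, although compound 2, which keeps the amide hydrogen, also stands apart from compound 1 and goes against tying the gain to loss of that hydrogen alone. No measured data offer a reason for these steps.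

Still open, on these data alone, is whether this flat response continues with a propyl or isopropyl group on the nitrogen, or with a chain ending in an amine. Methyl(phenyl)amino on the carbonyl carbon would test the effect of replacing the amide hydrogen of compound 2 directly.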